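The compounds below may be only part of what the source reports. "The series", "measured", "known", "first", "only" and "open" are said of these compounds alone.

Within the data shown here, compound 1 `CC1=CC[C@H](C(C)(C)NC(=S)N/N=C/c2ccc(O)cc2)CC1` gives 82100 nM in a functional assay on NCI/ADR-RES cells (Homo sapiens) for inhibition, read by sulforhodamine B assay, with a stated time of 48 h (on this read-out lower numbers stand for stronger inhibition of growth and higher numbers for weaker inhibition of growth), the higher of the two numbers measured so far. Among the measured compounds shown here, compound 2 `CC1=CC[C@H](C(C)(C)NC(=S)N/N=C/c2ccc(Cl)cc2)CC1` gives 65200 nM in this assay, and the only measured step, a 1.3-fold lower number from compound 1 to compound 2 (0.10 log units; within the scatter), stays within the scatter. Compound 3 `COc1cc(/C=N/NC(=S)NC(C)(C)[C@H]2CC=C(C)CC2)ccc1O` differs from compound 1 by methoxy in place of hydrogen on an aromatic carbon. For the measured compounds named here, no measured step adds a methoxy at this place, and the one available step changed a different position without moving the number beyond the scatter. For compound 3 the expected outcome in this assay is therefore a step of a 1.0-fold lower number from compound 1 to compound 3 (0.01 log units; within the scatter), no larger than the scatter, with an estimate of 80000 nM, between 35000 nM and 180000 nM.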

Compound 3, concentration for 50% growth inhibition: 23900 nM
The estimate for compound 3 lay 3.3-fold (0.52 log units) above the measured number; measured number below the stated range.
By their numbers in this assay, from the lowest: compound 3; then compounds 2 and 1 (each within the scatter of the next).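

A methoxy group on the aromatic carbon ortho to the hydroxy group lowers the number in this assay beyond the scatter (a 3.4-fold lower number from compound 1 to compound 3 (0.54 log units; beyond the scatter)), a modest step. The only earlier step, chloro in place of hydroxy, stayed within the scatter, so this is the first change shown to move the number. Nothing available explains this shift.

On these data alone, whether an ethoxy group or a fluoro group at this same place would give a similar step remains open, as does whether the methoxy step would persist with an amine in place of the hydroxy group.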